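A few compounds are considered here, and "the series" means these few. Any claim that something is new, unique, unknown or untested is made for them only; others in the source may bear on it.

In a functional assay on MCF7 cells (Homo sapiens) for cytotoxicity, read by sulforhodamine B assay, with a stated time of 48 h (on this read-out lower numbers stand for stronger inhibition and higher numbers for weaker inhibition), compound 1 `Cc1ccccc1NS(=O)(=O)c1cccc(NC(=O)NCCCCl)c1` gives 52000 nM, compound 2 `CCc1ccccc1NS(=O)(=O)c1cccc(NC(=O)NCCCCl)c1` gives 43000 nM and compound 3 `CCCc1ccccc1NS(=O)(=O)c1cccc(NC(=O)NCCCCl)c1` gives 18000 nM. Compound 2 therefore stands level with compound 1 within the scatter, while compound 3 lies lower. Compound 4 `CCNC(=O)Nc1cccc(S(=O)(=O)Nc2ccccc2CC)c1` follows from compound 2 through hydrogen in place of chloromethyl on a saturated chain carbon, two bonds along the chain from an amide-type nitrogen. Going by the values given here, no measured step touches that place, so the guidance is only loose. Chain growth elsewhere gave a 1.2-fold lower number from compound 1 to compound 2 (0.08 log units; within the scatter) and then a 2.4-fold lower number from compound 2 to compound 3 (0.38 log units; beyond the scatter). A modest move to a higher number is therefore expected, namely a 2.1-fold higher number from compound 2 to compound 4 (0.32 log units; beyond the scatter). For compound 4 the estimated value is 90000 nM, within an expected range of 35000 nM to 200000 nM.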

Compound 4, half-maximal inhibitory concentration: 48000 nM
For compound 4 the middle estimate is 1.9-fold (0.27 log units) above the measured one; low and high end bracket the measured number.
By their numbers in this assay, from the lowest: compound 3; then compounds 2, 4 and 1 (each within the scatter of the next).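

In this assay, going by these compounds alone, the change from 3-chloropropyl to ethyl gives a 1.1-fold higher number from compound 2 to compound 4 (0.05 log units; within the scatter), so this is the first evidence on this place, and removing chloromethyl there leaves compound 4 level with compound 2. Among the compounds shown, the chlorine-bearing end of the chain therefore makes no difference beyond the scatter on this background. No accompanying measurement bears on this result.

From the compounds shown here alone, it remains open whether an amine or a longer chain at this place would shift the number. Going by these compounds, it also remains open whether the same loss of chloromethyl would leave compound 3 unchanged.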